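A few compounds are considered here, and "the series" means these few. Any claim that something is new, unique, unknown or untested is made for them only; others in the source may bear on it.

Measured so far: compound 1 `CCOc1cccc2c1C(=O)N(Cc1cc(Br)ccc1NC(=O)c1ccccn1)C2=O`, 720 nM; compound 2 `O=C(Nc1ccc(Cl)cc1CN1C(=O)c2ccc(F)cc2C1=O)c1ccccn1`, 330 nM; compound 3 `O=C(Nc1ccc(Cl)cc1CN1C(=O)c2ccccc2C1=O)c1ccccc1`, > 100000 nM.

In an assay on CHO cells for positive allosteric modulation of metabotropic glutamate receptor 5 (Homo sapiens), read by FLIPR (on this read-out lower numbers stand for an effect already at smaller amounts and higher numbers for an effect only at larger amounts of compound), compound 1 gives 720 nM and compound 2 gives 330 nM. For compound 3 the reported value > 100000 nM is a limit of the assay, not a number, so compound 3 stands at the limit of > 100000 nM in this assay, at which 1 of the 3 values shown sits. Compound 4 `O=C(Nc1ccc(Cl)cc1CN1C(=O)c2ccccc2C1=O)c1ccccc1C(F)(F)F` differs from compound 3 by a single change: trifluoromethyl in place of hydrogen on an aromatic carbon. Among the measured compounds shown here, no measured pair shows this change, so the expectation rests only on the limit of compound 3. The step of an at least 3.3-fold lower number from compound 3 to compound 4 (0.52 log units; beyond the scatter) is expected to be small, with compound 4 most likely remaining near the limit or moving only slightly toward measurable potency. Compound 4 is therefore estimated at about 30000 nM, within a range from 3000 nM to 100000 nM.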

Compound 4, half-maximal effective concentration: 5700 nM
Compound 4: the middle estimate sits 5.3-fold (0.72 log units) above what was measured; the range from low to high includes it.
By their numbers in this assay, from the lowest: compound 2; then compound 1; then compound 4. At a limit, above all of these: compound 3.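

In this assay, trifluoromethyl in place of hydrogen on an aromatic carbon, ortho to a large group, gives an at least 17-fold lower number from compound 3 to compound 4 (1.24 log units; beyond the scatter) and so brings a measurable value with no other change to the compound. For compound 3, the value > 100000 nM is a limit of the assay. The step therefore gives only a minimum size, since its starting point is that limit: the limit of > 100000 nM in this assay, at which 1 of the 4 values shown sits.

From the compounds shown here alone, whether a methyl, a methoxy or an amine at this place would give a step of similar size stays open. So does whether trifluoromethyl would act alike elsewhere on this ring.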